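The compounds below may be only part of what the source reports. "The series", "measured", "known", "first", "only" and "open" are said of these compounds alone.

Measured so far in a functional assay on NCI-H460 cells (Homo sapiens) for antiproliferative activity, with a stated time of 72 h; on this read-out lower numbers stand for stronger inhibition and higher numbers for weaker inhibition:
compound 1 `C=CC[C@H]1C[C@]2([C@H](C)Cc3ccc(OC)cc3)OCOC2=CC1=O` gives 120 nM
compound 2 `C=CC[C@H]1C[C@]2([C@@H](C)Cc3cc(F)c(OC)cc3F)OCOC2=CC1=O` gives 59 nM
compound 3 `C=CC[C@H]1C[C@]2([C@H](C)Cc3cc(F)c(OC)cc3F)OCOC2=CC1=O` gives 35 nM

In this assay compound 3 sits at the low end of the three numbers. Compound 2 lies within the scatter of it, as the step of a 1.7-fold lower number from compound 2 to compound 3 (0.23 log units; within the scatter) shows; compound 1 lies beyond the scatter. For the measured compounds named here, the only single-place step measured is the one from compound 2 to compound 3, and it rests on (the fact that compounds 2 and 3 differ only in the configuration as drawn), so it says nothing about a change of substituent on the aromatic ring.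

Compound 4 `C=CC[C@H]1C[C@]2([C@H](C)Cc3cc(O)c(OC)cc3F)OCOC2=CC1=O` is not yet measured. It differs from compound 3 by hydroxy in place of fluoro on an aromatic carbon. Going by the values given here, no measured step covers a change of this kind: the difference between compound 1 and compound 3 combines two added fluoro groups with a change of configuration, and the step from compound 2 to compound 3 is a change of configuration alone. With nothing to go on but the shared core and the unchanged allyl, methyl and methoxy groups, compound 4 is expected to stay close to compound 3, with a step of a 1.4-fold higher number from compound 3 to compound 4 (0.15 log units; within the scatter) not clearly beyond the scatter. The estimate for compound 4 in this assay is 50 nM, with a range from 15 nM to 170 nM.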

Compound 4, half-maximal inhibitory concentration: 15 nM
Beside the measured number, compound 4's estimate is 3.3-fold (0.52 log units) above it, within the range that was stated.
By their numbers in this assay, from the lowest: compound 4; then compounds 3 and 2 (each within the scatter of the next); then compound 1.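

In this assay, the aromatic carbon ortho to a methoxy group and para to a fluoro group now has a single-place reading for a change of substituent: hydroxy in place of fluoro gives a 2.3-fold lower number from compound 3 to compound 4 (0.37 log units; beyond the scatter). For the compounds shown here, the one earlier single-place step, a 1.7-fold lower number from compound 2 to compound 3 (0.23 log units; within the scatter), is a change of configuration alone and within the scatter, so it carried no information about this ring position, whereas this change, which enters one hydrogen-bond donor and one hydrogen-bond acceptor where fluoro has none, gives a modest step beyond the scatter and shows that fluoro is not required at this carbon for a low number. Nothing available bears on why the number falls with this change.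

Open, on these data alone, is whether an amine or a carboxylic acid on this aromatic carbon would read like hydroxy or like fluoro, and whether a methoxy group there would keep the step. Also open, as far as these compounds go, is whether the step holds with the other drawn configuration at the saturated chain carbon, as in compound 2, or without the fluoro group para to this carbon.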